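This account rests on a few compounds, and the source may have more. Where it says the series, first, only, none or still open, it means among the compounds named here.

Measured compounds:
Compound 1, `O=C(/C=C/c1ccc(O)cc1)c1c(O)cccc1OCc1ccccc1`, gives > 30000 nM in a functional assay on HCT-15 cells (Homo sapiens) for antiproliferative activity, read by sulforhodamine B assay; on this read-out higher numbers stand for weaker inhibition of growth and lower numbers for stronger inhibition of growth; this is a limit of the assay, not a number.
Compound 2, `CC(C)CCCOc1cccc(O)c1C(=O)/C=C/c1ccc(O)cc1`, gives 11600 nM in this assay.
Compound 3, `O=C(/C=C/c1ccc(O)cc1)c1c(O)cccc1OCCC1CCCCC1`, gives > 30000 nM in this assay; this too is a limit, not a number.

Going by these compounds, compound 3 thus stands at the limit of > 30000 nM in this assay, at which 2 of the 3 values shown sit, so its true value is unknown beyond that boundary. Compound 4, `CCC(CC)COc1cccc(O)c1C(=O)/C=C/c1ccc(O)cc1`, differs from compound 3 by pentan-3-yl in place of cyclohexylmethyl on a saturated chain carbon bound to an oxygen on an aromatic ring. The ring of compound 3 leaves and a branched five-carbon chain enters, which makes compound 4 a close relative of compound 2, whose isopentyl chain is also branched and five carbons long. The most telling measured step is an at least 2.5-fold higher number from compound 2 to compound 3 (0.41 log units; beyond the scatter), and the step from compound 3 to compound 4 reverses that kind of change. The step of an at least 2.5-fold lower number from compound 1 to compound 2 (0.41 log units; beyond the scatter) shows that a branched chain in this place reads better than a ring. For compound 4 a lower number than the limit of compound 3 is therefore expected, roughly an at least 2.0-fold lower number from compound 3 to compound 4 (0.30 log units; that floor lies within the scatter), though the limit keeps the exact size unreadable. The estimate for compound 4 in this assay is 15000 nM, within 6000 nM to 40000 nM.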

Compound 4, concentration for 50% growth inhibition: 3420 nM
Compound 4: the middle estimate sits 4.4-fold (0.64 log units) above what was measured; the whole stated range lies above it.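

On this saturated chain carbon, the choice between two open chains matters, not just the choice of a chain over a ring: swapping isopentyl for pentan-3-yl gives a 3.4-fold lower number from compound 2 to compound 4 (0.53 log units; beyond the scatter) in this assay. Pentan-3-yl also reads clearly better than both ring-bearing groups, with an at least 8.7-fold lower number from compound 3 to compound 4 (0.94 log units; beyond the scatter) against cyclohexylmethyl and an at least 8.7-fold lower number from compound 1 to compound 4 (0.94 log units; beyond the scatter) against phenyl. Compound 1 and compound 3 each sit at a limit, so these two steps give only a floor and their true size stays unknown: the limit of > 30000 nM in this assay, at which 2 of the 4 values shown sit.

The compounds shown leave open whether a longer chain at this place would lower the number further, or whether an unbranched pentyl chain would read like the branched ones. They also leave open how an amine on the chain would read in this assay.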